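Carbonyl substituent variation on the shared core

The compounds below may be only part of what the source reports. "The series", "measured", "known", "first", "only" and "open" are said of these compounds alone.

Measured in a functional assay on OVCAR-3 cells (Homo sapiens) for inhibition, read by sulforhodamine B assay, with a stated time of 48 h; a higher number here means a weaker inhibitor of growth, a lower number a stronger inhibitor of growth:

compound 1 `COc1cc(-c2nn(-c3cccc(NC(=O)c4cccc(C(F)(F)F)c4)c3)cc2-c2ccncc2)ccc1Cl`: 2980 nM
compound 2 `COc1cc(-c2nn(-c3cccc(NC(=O)Nc4cccc(C(F)(F)F)c4)c3)cc2-c2ccncc2)ccc1Cl`: 1870 nM

Compound 2 holds the lowest of the two numbers; its nearest neighbour is compound 1, and the step of a 1.6-fold lower number from compound 1 to compound 2 (0.20 log units; within the scatter) lies within the scatter, so the two are not separated.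

Compound 3 `COc1cc(-c2nn(-c3cccc(NC(=O)c4ccc(Cl)c(C(F)(F)F)c4)c3)cc2-c2ccncc2)ccc1Cl` is not yet measured. It differs from compound 2 in one place: 4-chloro-3-(trifluoromethyl)phenyl in place of (3-(trifluoromethyl)phenyl)amino on a carbonyl carbon. Within the data shown here, the only measured step that bears on this is the one from compound 1 to compound 2, where (3-(trifluoromethyl)phenyl)amino replaced 3-(trifluoromethyl)phenyl on the carbonyl carbon and gave a 1.6-fold lower number from compound 1 to compound 2 (0.20 log units; within the scatter). As far as these compounds go, compound 3 reverses that exchange and in addition carries a chlorine on the ring; for the chlorine no comparison exists, so its contribution is unknown. The step from compound 2 to compound 3 in this assay is therefore expected to be small, most likely a somewhat higher number in line with compound 1, and the estimated step is a 1.3-fold higher number from compound 2 to compound 3 (0.13 log units; within the scatter). For compound 3 the expected value in this assay is 2500 nM, with a range from 900 nM to 7000 nM.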

Compound 3, concentration for total growth inhibition: 19800 nM
Compound 3: middle estimate off by 7.9-fold (0.90 log units), on the low side; measured number outside the range, above it.
By their numbers in this assay, from the lowest: compounds 2 and 1 (each within the scatter of the next); then compound 3.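

In this assay, the ring on the carbonyl carbon proves sensitive to substitution: chloro in place of hydrogen on an aromatic carbon gives a 6.6-fold higher number from compound 1 to compound 3 (0.82 log units; beyond the scatter) and so separates two compounds, which the earlier exchange on the carbonyl carbon did not do, since it gave only a 1.6-fold lower number from compound 1 to compound 2 (0.20 log units; within the scatter) within the scatter. With 4-chloro-3-(trifluoromethyl)phenyl in place of (3-(trifluoromethyl)phenyl)amino, the change on the carbonyl carbon reaches an 11-fold higher number from compound 2 to compound 3 (1.02 log units; beyond the scatter) and is the only step among these compounds printed as large, so this exchange cannot be treated as neutral once the chlorine is present. Nothing measured here accounts for the rise in the number.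

Still open, as far as these compounds go, is whether the loss belongs to chlorine itself or would also follow from fluorine, a methyl or a methoxy group at the same ring carbon. Also open, from the compounds shown here alone, is whether (4-chloro-3-(trifluoromethyl)phenyl)amino on the carbonyl carbon would give the same rise, which would show whether the chlorine has the same effect with the nitrogen in place.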